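The source may report more compounds than this note shows. Statements on the series, on what has been measured and on what is new or still open speak of the compounds shown alone.

The measured compounds in a functional assay on SF-295 cells (Homo sapiens) for inhibition, read by sulforhodamine B assay, with a stated time of 48 h, tested at 10 uM; on this read-out lower numbers stand for less inhibition and higher numbers for more inhibition at the one concentration tested (going by the name of the read-out):
Compound 1 `COc1ccc(-c2cn3ccnc3c(-c3ccc4ncn(C5CCCCC5)c4c3)n2)cc1` gives 92.5%.
Compound 2 `O=Cc1ccc(-c2cn3ccnc3c(-c3ccc4ncn(C5CCCCC5)c4c3)n2)cc1` gives 23.1%.
Compound 3 `Clc1ccc(-c2cn3ccnc3c(-c3ccc4ncn(C5CCCCC5)c4c3)n2)cc1` gives 14.5%.

Compound 3 stands lowest of the three numbers in this assay; its nearest neighbour is compound 2, whose number is higher by a step within the scatter, and its furthest is compound 1, higher by a step beyond the scatter. The two large steps seen here both start from compound 1: a number 69.4 percentage points lower from compound 1 to compound 2 (beyond the scatter) and a number 78 percentage points lower from compound 1 to compound 3 (beyond the scatter). The step between the two lower compounds, a number 8.6 percentage points lower from compound 2 to compound 3 (within the scatter), lies within the scatter.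

Compound 4 `Brc1ccc(-c2cn3ccnc3c(-c3ccc4ncn(C5CCCCC5)c4c3)n2)cc1` differs from compound 3 by bromo in place of chloro on an aromatic carbon. Going by the values given here, no measured step shows this particular exchange of one halogen for another. The step that comes closest in kind is the one from a formyl to a chloro group, a number 8.6 percentage points lower from compound 2 to compound 3 (within the scatter), which did not move the number beyond the scatter. Because a number 8.6 percentage points lower from compound 2 to compound 3 (within the scatter) is within the scatter, the expectation for compound 4 is a step of no size beyond the scatter, a number 0.5 percentage points higher from compound 3 to compound 4 (within the scatter). The estimate for compound 4 in this assay is therefore 15%, with a range from 4% to 32%.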

Compound 4, a percentage reported as inhibition, at one concentration (the size of the read-out at that concentration, not a potency): 41.3%
Compound 4: the middle estimate sits 26.3 percentage points below what was measured; the whole stated range lies below it.
By their numbers in this assay, from the lowest: compounds 3 and 2 (each within the scatter of the next); then compound 4; then compound 1.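

In this assay the exchange of one halogen for another at this place, para to a large group, is not neutral: a number 26.8 percentage points higher from compound 3 to compound 4 (beyond the scatter) is a step beyond the scatter, although chloro and bromo each count one heavy atom and neither carries a hydrogen-bond donor or acceptor. Bromo also stands apart from formyl, as a number 18.2 percentage points higher from compound 2 to compound 4 (beyond the scatter) shows, whereas chloro and formyl had remained within the scatter of each other, yet methoxy still stays well clear of bromo, with a number 51.2 percentage points lower from compound 1 to compound 4 (beyond the scatter) as the step. Nothing measured here explains why these groups fall in this order.

Going by these compounds, whether fluoro or iodo would extend the difference between chloro and bromo stays open, as does whether an amine, a carboxylic acid or a longer alkoxy chain would stand nearer to methoxy or to the halogens. The numbers also come from one concentration in this assay and leave open how the four compounds would compare across a range of concentrations or in other cell lines.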